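Urea series on the shared core: a halogenated aryl swap

The source may report more compounds than this note shows. Statements on the series, on what has been measured and on what is new or still open speak of the compounds shown alone.

Measured so far:
compound 1 `COc1cc(Nc2ncnc3c(NC(=O)Nc4cccc(Oc5ccccc5)c4)cccc23)cc(OC)c1`: 14000 nM
compound 2 `COc1cc(Nc2ncnc3c(NC(=O)Nc4ccc(F)cc4C(F)(F)F)cccc23)cc(OC)c1`: 2970 nM

In a functional assay on RT-112 cells (Homo sapiens) for antiproliferative activity, read by MTT assay, with a stated time of 72 h (a lower number here means a stronger inhibitor of growth, a higher number a weaker inhibitor of growth), compound 2 gives the lowest of the two numbers, with compound 1 a clearly higher number beyond the scatter. Compound 3 `COc1cc(Nc2ncnc3c(NC(=O)Nc4ccc(C(F)(F)F)cc4Cl)cccc23)cc(OC)c1` is not yet measured. It differs from compound 2 as follows: 2-chloro-4-(trifluoromethyl)phenyl in place of 4-fluoro-2-(trifluoromethyl)phenyl on an amide-type nitrogen. Within the data shown here, no measured step matches this change, so the step of a 1.2-fold lower number from compound 2 to compound 3 (0.07 log units; within the scatter) is expected to stay within the scatter, no clear direction. Compound 3 is therefore estimated at 2500 nM, with a range from 800 nM to 8000 nM.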

Compound 3, concentration for 50% growth inhibition: 1080 nM
For compound 3 the middle estimate is 2.3-fold (0.36 log units) above the measured one; the measured number falls inside the stated range.
By their numbers in this assay, from the lowest: compound 3; then compound 2; then compound 1.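

In this assay, the aryl group on the amide-type nitrogen can shift the number even when heavy-atom count stays the same: 2-chloro-4-(trifluoromethyl)phenyl in place of 4-fluoro-2-(trifluoromethyl)phenyl gives a 2.8-fold lower number from compound 2 to compound 3 (0.44 log units; beyond the scatter). The two groups also match in ring type and in hydrogen-bond donors and acceptors, so this position responds to the identity and arrangement of the substituents alone. Nothing available here bears on why the number moves.

As far as these compounds go, it remains open how much of the step belongs to the chlorine and how much to the rearranged fluorinated groups. From the compounds shown here alone, a morpholine or a carboxylic acid on this aryl ring also remains untested ground for the series.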